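Dropping the Bromo Substituent: An Expected Small Step

A few compounds are considered here, and "the series" means these few. Any claim that something is new, unique, unknown or untested is made for them only; others in the source may bear on it.

Of the compounds shown here, two have so far been measured in an ADME assay on 184B5 cells (Homo sapiens) for cytotoxicity, read by sulforhodamine B assay, with a stated time of 48 h; on this read-out higher numbers stand for weaker inhibition of growth and lower numbers for stronger inhibition of growth. Compound 1 `NC(=S)N/N=C1/C(=O)N(CN2CCN(c3ccnc4cc(Cl)ccc34)CC2)c2ccccc21` gives 28800 nM in this assay. Compound 2 `NC(=S)N/N=C1/C(=O)N(CN2CCN(c3ccnc4cc(C(F)(F)F)ccc34)CC2)c2cc(Br)ccc21`, which carries a trifluoromethyl group on one ring system and a bromo group on another, gives 21400 nM in this assay. These two values lie within the usual scatter of each other, so neither compound can be called the stronger or weaker inhibitor of growth on this evidence.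

Compound 3 `NC(=S)N/N=C1/C(=O)N(CN2CCN(c3ccnc4cc(C(F)(F)F)ccc34)CC2)c2ccccc21` has not yet been measured. It differs from compound 2 in a single place: hydrogen in place of bromo on an aromatic carbon. Among the measured compounds shown here, no pair of measured compounds shows this change on its own, so the data give no direction for it. Since compound 1 and compound 2 differ in more than one place and still sit within the scatter, the bromo group appears to carry little weight here; the step from compound 2 to compound 3 is expected to be a 1.2-fold higher number from compound 2 to compound 3 (0.08 log units; within the scatter), nothing beyond the scatter. Compound 3 is therefore estimated to give 26000 nM in this assay, with a range from 10000 nM to 70000 nM.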

Compound 3, concentration for 50% growth inhibition: 20200 nM
The estimate for compound 3 lay 1.3-fold (0.11 log units) above the measured number, within the range that was stated.
By their numbers in this assay, from the lowest: compounds 3, 2 and 1 (each within the scatter of the next).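

In this assay, hydrogen in place of bromo on the aromatic carbon, meta to a fused ring and para to a fused ring, gives a 1.1-fold lower number from compound 2 to compound 3 (0.03 log units; within the scatter) as a single replacement, so at this position the two substituents cannot be told apart in this read-out. The second single-place comparison, trifluoromethyl in place of chloro on an aromatic carbon, gives a 1.4-fold lower number from compound 1 to compound 3 (0.15 log units; within the scatter) and likewise does not separate the two compounds, so neither replacement moves the number beyond the usual scatter in these pairs. Nothing available bears on why these replacements leave the compounds indistinguishable.

The compounds shown leave open whether a group of another kind on the aromatic carbon that held bromo, such as an amine, a carboxylic acid or a longer chain, would give a number beyond the scatter of those of compound 2 and compound 3. They also leave open whether the bromo group would behave in the same way alongside chloro instead of trifluoromethyl, since the pair that would show this is not among them.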